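Removing the ring methyl from a chromone with a long chain

This account rests on a few compounds, and the source may have more. Where it says the series, first, only, none or still open, it means among the compounds named here.

Compound 1, `CCCC/C=C\CCCCCCCCCc1cc(=O)c2c(O)cc(O)c(C)c2o1`, is one of three compounds sharing a core that carries a long chain and differing only in that chain. In a functional assay on MCF7 cells (Homo sapiens) for antiproliferative activity, read by MTT assay (on this read-out lower numbers stand for stronger inhibition and higher numbers for weaker inhibition), compound 1 gives 17500 nM. Compound 2, `CCCCCCCCCCCCCCCc1cc(=O)c2c(O)cc(O)c(C)c2o1`, gives 17500 nM in this assay, and compound 3, `CC/C=C\C/C=C\C/C=C\CCCCCCCc1cc(=O)c2c(O)cc(O)c(C)c2o1`, gives 17500 nM. Compound 1 thus stands level with both: the step of no change at the digits printed from compound 1 to compound 2 (within the scatter) and the step of no change at the digits printed from compound 1 to compound 3 (within the scatter), like the step of no change at the digits printed from compound 2 to compound 3 (within the scatter), all lie within the scatter, so the chain variations seen so far leave this assay unmoved.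

Compound 4, `CCCC/C=C\CCCCCCCCCc1cc(=O)c2c(O)cc(O)cc2o1`, differs from compound 1 in the core rather than the chain: hydrogen in place of methyl on an aromatic carbon. Within the data shown here, none of the three measured steps touches the core, so no measured step bears directly on this change; the only guidance is that compound 1 and its neighbours sit at a common level that proved insensitive to the alterations tried. In the absence of any step at this position, the expectation for compound 4 is a step of no change at the digits printed from compound 1 to compound 4 (within the scatter) that does not go beyond the scatter, and compound 4 is therefore estimated at 17500 nM in this assay, with a plausible range from 7000 nM to 45000 nM.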

Compound 4, half-maximal inhibitory concentration: 17500 nM
The estimate for compound 4 equals the measured number at the digits printed; low and high end bracket the measured number.
By their numbers in this assay, from the lowest: compounds 1, 2, 3 and 4 (each within the scatter of the next).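

Among these compounds, until compound 4, every measured change lay in the long chain, so the methyl on the aromatic carbon, para to a hydroxy group, is the first place in the shared core where a change can be read. In this assay, hydrogen in place of methyl gives no change at the digits printed from compound 1 to compound 4 (within the scatter), so this methyl can be removed without a step beyond the scatter, at least with the long chain that these two compounds share. No measurement shown gives a reason for this result.

Hydrogen is the only replacement for the methyl shown here, so it remains open whether ethyl, chlorine or a methoxy group at the same carbon would leave the read-out where it is, and whether removing the methyl would read the same with the chains of compound 2 and compound 3. From the compounds shown here alone, all four compounds sit at one level, so it is also open whether any change can move this series in this assay, such as a methoxy group in place of a hydroxy group, or an amine or a carboxylic acid at the end of the chain.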